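Changing the benzyl group on a triazole amide

The source may hold more compounds than are shown below. What is called first, only, known or untested is meant among the compounds shown, and "the series" means these compounds.

Measured so far:
Compound 1 `O=C(NCc1cn(Cc2ccc(F)cc2)nn1)c1cn(-c2ccccc2)nc1-c1ccc(F)cc1` — 55300 nM
Compound 2 `O=C(NCc1cn(Cc2ccc(C(F)(F)F)cc2)nn1)c1cn(-c2ccccc2)nc1-c1ccc(F)cc1` — 810 nM

In a functional assay on MCF7 cells (Homo sapiens) for antiproliferative activity, read by sulforhodamine B assay, with a stated time of 48 h (on this read-out lower numbers stand for stronger inhibition of growth and higher numbers for weaker inhibition of growth), compound 2 holds the lower of the two numbers. Among the compounds with values here, the one measured step, a 68-fold lower number from compound 1 to compound 2 (1.83 log units; beyond the scatter), shows that a change at this position can move the read-out strongly. Compound 3 `COc1ccc(Cn2cc(CNC(=O)c3cn(-c4ccccc4)nc3-c3ccc(F)cc3)nn2)cc1OC` differs from compound 2 by 3,4-dimethoxyphenyl in place of 4-(trifluoromethyl)phenyl on a saturated chain carbon bound to an aromatic nitrogen. On these data alone, that single step bears on it only as a sign of how large such changes can be; its direction for this new group is unknown. A moderately higher number is expected for compound 3, a 6.2-fold higher number from compound 2 to compound 3 (0.79 log units; beyond the scatter). The estimate for compound 3 is 5000 nM, within 700 nM to 40000 nM.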

Compound 3, concentration for 50% growth inhibition: > 100000 nM
Compound 3: a limit, no number; the forecaster's own chance of this, stated with the estimate: 10%; at least 20-fold (1.30 log units) between middle value and limit.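

Putting 3,4-dimethoxyphenyl in place of 4-(trifluoromethyl)phenyl gives an at least 120-fold higher number from compound 2 to compound 3 (2.09 log units; beyond the scatter), so large shifts at this position are now seen in both directions. Against the 4-fluorophenyl group, the same replacement gives an at least 1.8-fold higher number from compound 1 to compound 3 (0.25 log units; that floor lies within the scatter), so the data do not firmly separate compound 1 from compound 3. The result for compound 3 is a limit of the assay and not a number: the limit of > 100000 nM in this assay, at which 1 of the 3 values shown sits.

The compounds shown leave open where a plain benzyl or a 4-methoxybenzyl would fall, and so whether one methoxy group alone would give the same result as two.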